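The compounds below may be only part of what the source reports. "The series", "measured", "known", "first", "only" and "open" are said of these compounds alone.

Measured compounds:
Compound 1 `CCN(CC)C(=O)Cc1c(-c2ccc(OCC3CCCCC3)cc2)nn2c(C)cc(C)nc12` gives 3.6 nM in an assay on isolated protein (kidney, strain Wistar) for displacement of a labelled ligand from Translocator protein (Rattus norvegicus), read by scintillation counting, with a stated time of 90 min; a lower number here means a stronger inhibitor, a higher number a weaker inhibitor.
Compound 2 `CCN(CC)C(=O)Cc1c(-c2ccc(OCc3ccc(F)cc3)cc2)nn2c(C)cc(C)nc12` gives 0.77 nM in this assay.

Among the compounds with values here, compound 2 has the lowest number of the two measured compounds, and its only neighbour is compound 1, with a gap of a 4.7-fold lower number from compound 1 to compound 2 (0.67 log units; beyond the scatter). Within the data shown here, that single step, 4-fluorophenyl in place of cyclohexyl on a saturated chain carbon bound to an oxygen on an aromatic ring, is the only measured change, and it concerns the whole ring rather than one of its substituents.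

Compound 3 `CCN(CC)C(=O)Cc1c(-c2ccc(OCc3ccc(C(F)(F)F)cc3)cc2)nn2c(C)cc(C)nc12` is not yet measured. It differs from compound 2 by trifluoromethyl in place of fluoro on an aromatic carbon, placed on an aromatic carbon of a six-membered aromatic ring of carbon only, para to a large group. Among the measured compounds shown here, no measured step swaps one small group for another on that ring, so the step from compound 1 to compound 2 bears on it only loosely. The expectation is therefore a step in this assay of a 1.7-fold higher number from compound 2 to compound 3 (0.23 log units; within the scatter), small and possibly within the scatter. Compound 3 is estimated at 1.3 nM, with a range of 0.4 nM to 4.5 nM.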

Compound 3, inhibition constant: 1.6 nM
Beside the measured number, compound 3's estimate is 1.2-fold (0.09 log units) below it; low and high end bracket the measured number.
By their numbers in this assay, from the lowest: compound 2; then compound 3; then compound 1.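

Until now only a whole ring at the end of the chain had changed; here a single substituent on that ring changes, on an aromatic carbon para to a large group. In this assay, trifluoromethyl in place of fluoro gives a 2.1-fold higher number from compound 2 to compound 3 (0.32 log units; beyond the scatter), so what sits at this position does affect the number, although the step is modest. The change from cyclohexyl to an aromatic ring still gives a lower number with the new substituent, with a 2.3-fold lower number from compound 1 to compound 3 (0.35 log units; beyond the scatter), so that gain is not tied to fluoro alone. No independent measurement is available here to explain the direction or size of either step.

On these data alone, with only fluoro and trifluoromethyl seen at this position, it remains open how a chlorine atom, a methoxy group or an amine would behave there, and whether the number follows any simple trend across such groups. As far as these compounds go, the diethyl amide is also the same in all three compounds, so the effect of a longer chain on its nitrogen, and whether it would combine simply with the change on the ring, remains unknown.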